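The source may hold more compounds than are shown below. What is called first, only, known or untested is meant among the compounds shown, and "the series" means these compounds.

Of the compounds shown here, two sharing one core have been measured in a functional assay on A549 cells (Homo sapiens) for antiproliferative activity, read by MTT assay, with a stated time of 72 h; a higher number here means a weaker inhibitor, a lower number a stronger inhibitor. Compound 1 (`O=C(N/N=C/c1ccc(Br)cc1)Nc1ccc(Oc2ccnc3[nH]ccc23)c(F)c1`), which carries a 4-bromophenyl group, gives 820 nM. Compound 2 (`O=C(N/N=C/c1ccc(Cl)c(Cl)c1)Nc1ccc(Oc2ccnc3[nH]ccc23)c(F)c1`), which carries a 3,4-dichlorophenyl group, gives 2650 nM, the higher of the two numbers and so the weaker inhibitor of the pair. Compound 3 (`O=C(N/N=C/c1ccc(F)cc1Cl)Nc1ccc(Oc2ccnc3[nH]ccc23)c(F)c1`) keeps the core and alters one group: 2-chloro-4-fluorophenyl in place of 3,4-dichlorophenyl on a carbon with a double bond to nitrogen. In words, 2-chloro-4-fluorophenyl stands in place of 3,4-dichlorophenyl on a carbon with a double bond to nitrogen. Going by the values given here, only one measured step bears on this change, a 3.2-fold higher number from compound 1 to compound 2 (0.51 log units; beyond the scatter), a modest move beyond the scatter at the same place. Among the compounds with values here, no measured compound carries the entering group, so the direction rests on thin evidence. With compound 2 at 2650 nM standing at the top of the two values, a small move towards a lower number seems the likelier outcome. The expected size is a 1.8-fold lower number from compound 2 to compound 3 (0.25 log units; within the scatter), an estimate of no more than a modest change. The estimate in this assay for compound 3 is 1500 nM, with an expected range from 500 nM to 4500 nM.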

Compound 3, half-maximal inhibitory concentration: 10 nM
Compound 3: middle estimate off by 150-fold (2.18 log units), on the high side, outside the stated range (below it).
By their numbers in this assay, from the lowest: compound 3; then compound 1; then compound 2.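

The earlier pair showed only a modest spread at this place, on a carbon with a double bond to nitrogen, whereas the new result shows that a change of aryl group here can move the number far more, and that halogen-bearing phenyl groups are not interchangeable in this assay (the step is a 270-fold lower number from compound 2 to compound 3 (2.42 log units; beyond the scatter) and, against the 4-bromophenyl group, an 82-fold lower number from compound 1 to compound 3 (1.91 log units; beyond the scatter)). Both steps lie beyond the scatter and make compound 3 the strongest inhibitor of the three. The 3,4-dichlorophenyl and 2-chloro-4-fluorophenyl groups have the same count of heavy atoms, no hydrogen-bond donors or acceptors and no net charge, so those counts do not separate them, and nothing available explains the difference.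

The compounds shown leave open whether the chlorine or the fluorine of the 2-chloro-4-fluorophenyl group matters more, or whether only the two together give so low a number. They also leave open how a phenyl group without halogen, or one carrying a methoxy group or an amine, would behave at this place.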